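Amide Chain Length and Paw Edema Inhibition in Rats

The compounds below may be only part of what the source reports. "The series", "measured", "known", "first", "only" and "open" are said of these compounds alone.

Compound 1 `CNC(=O)CC1CCc2cc(OC)c(OC)cc21`: 33.3%
Compound 2 `CCNC(=O)CC1CCc2cc(OC)c(OC)cc21`: 33.3%
Compound 3 `CCCCCNC(=O)CC1CCc2cc(OC)c(OC)cc21`: 46.7%

Three measured compounds share one core and were tested in a functional assay on the whole organism (strain Wistar) for inhibition, with Rattus norvegicus as the target, read by paw edema, with stated times of 60 min and 24 h, at a dose of 100 mg/kg by the oral route; a lower number here means less inhibition, a higher number more inhibition at the dose given (going by the name of the read-out). Compound 1 gives 33.3% in this assay, compound 2 gives 33.3%, and compound 3 gives 46.7%. The change from compound 1 to compound 2 is methyl in place of hydrogen on a saturated chain carbon bound to an amide-type nitrogen, and it made a step of no change at the digits printed from compound 1 to compound 2 (within the scatter). Compound 3 differs from compound 1 by butyl in place of hydrogen on a saturated chain carbon bound to an amide-type nitrogen, giving a number 13.4 percentage points higher from compound 1 to compound 3 (beyond the scatter); from compound 2 the step is a number 13.4 percentage points higher from compound 2 to compound 3 (beyond the scatter).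

Compound 4 `CCCCCCNC(=O)CC1CCc2cc(OC)c(OC)cc21` is not yet measured. It differs from compound 3 by methyl in place of hydrogen on a saturated chain carbon, five bonds along the chain from an amide-type nitrogen. This is the same kind of change as from compound 1 to compound 2, but the place differs: there the methyl enters on a carbon bound to an amide-type nitrogen, here on a carbon five bonds along the chain from that nitrogen. Because the earlier addition of one carbon gave no change at the digits printed from compound 1 to compound 2 (within the scatter), compound 4 is expected to move only slightly, by a number 3.3 percentage points higher from compound 3 to compound 4 (within the scatter). Compound 4 is therefore estimated at 50%, between 35% and 63%.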

Compound 4, a percentage reported as inhibition, in the whole organism at one dose (the size of the read-out at that dose, not a potency): 45.5%
Compound 4: middle estimate off by 4.5 percentage points, on the high side; low and high end bracket the measured number.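

Carrying the methyl in place of hydrogen onto the longer chain gave a number 1.2 percentage points lower from compound 3 to compound 4 (within the scatter) in this assay, and this step agrees with the earlier one: the same change on two cores in this assay, no change at the digits printed (within the scatter) from compound 1 to compound 2 and a number 1.2 percentage points lower (within the scatter) from compound 3 to compound 4, 1.2 percentage points apart, within the scatter of two such steps. The butyl change gave a number 12.2 percentage points higher from compound 2 to compound 4 (beyond the scatter), matching its earlier counterpart, while the pentyl change gave a number 12.2 percentage points higher from compound 1 to compound 4 (beyond the scatter): the same change on two cores in this assay, a number 13.4 percentage points higher (beyond the scatter) from compound 1 to compound 3 and a number 12.2 percentage points higher (beyond the scatter) from compound 2 to compound 4, 1.2 percentage points apart, within the scatter of two such steps. This shows that these changes read alike on the cores compared here at the single dose of this assay, but it does not show that they would carry over to any other core, nor does it give a potency.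

The compounds shown leave open how a longer chain would read. They also leave open whether an amine or a carboxylic acid on the chain would change the result.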